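Methoxy for tert-butyl on the anilino ring of compound 2

A few compounds are considered here, and "the series" means these few. Any claim that something is new, unique, unknown or untested is made for them only; others in the source may bear on it.

Measured so far:
Compound 1 `Brc1cccc(Nc2nc(-c3ccncc3)cs2)c1`: 40700 nM
Compound 2 `CC(C)(C)c1cccc(Nc2nc(-c3ccncc3)cs2)c1`: 60300 nM

Compound 2 gives the highest number of the two measured in a functional assay on RCC4 cells (Homo sapiens) for inhibition, read by XTT assay, with a stated time of 4 days (on this read-out lower numbers stand for stronger inhibition and higher numbers for weaker inhibition), though its nearest neighbour, compound 1, lies within the scatter of it, so the two cannot be ranked against each other. For the measured compounds named here, the step from compound 1 to compound 2 is a 1.5-fold higher number from compound 1 to compound 2 (0.17 log units; within the scatter), and it is the only measured step in this set.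

Compound 3 `COc1cccc(Nc2nc(-c3ccncc3)cs2)c1` is the next compound, differing from compound 2 by methoxy in place of tert-butyl on an aromatic carbon. Going by the values given here, the one measured step, a swap at the same place on the same ring, bears on this change only loosely, since it exchanged bromo for tert-butyl rather than tert-butyl for methoxy, and it stayed within the scatter. On that basis no step beyond the scatter is expected in this assay for the new group either. Compound 3 is therefore expected to give about 45000 nM in this assay, within a range of 15000 nM to 135000 nM. This estimate means a step of a 1.3-fold lower number from compound 2 to compound 3 (0.13 log units; within the scatter), a change that would stay within the scatter.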

Compound 3, half-maximal inhibitory concentration: 3020 nM
Beside the measured number, compound 3's estimate is 15-fold (1.17 log units) above it; the whole stated range lies above it.
By their numbers in this assay, from the lowest: compound 3; then compounds 1 and 2 (each within the scatter of the next).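

Compound 1 and compound 2 had suggested that the group at this place on the aromatic ring of carbon only made little difference in this assay, but methoxy shows otherwise, with a 20-fold lower number from compound 2 to compound 3 (1.30 log units; beyond the scatter) against tert-butyl and a 13-fold lower number from compound 1 to compound 3 (1.13 log units; beyond the scatter) against bromo. Bromo and tert-butyl still cannot be told apart, at a 1.5-fold higher number from compound 1 to compound 2 (0.17 log units; within the scatter), whereas compound 3 stands clear of both, so the position responds to the choice of group even though that first swap did not reveal it. Methoxy differs from tert-butyl in having fewer heavy atoms and in counting a hydrogen-bond acceptor, but no available evidence connects the lower number in this assay with either difference.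

The compounds shown leave open whether the oxygen or the smaller group matters more, and whether hydroxy, ethoxy or an amine at this place would keep, extend or lose the lower number. They also leave open whether methoxy would act the same way elsewhere on the ring, as all three compounds carry their group at this one place.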